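The source may hold more compounds than are shown below. What is called first, only, known or untested is meant among the compounds shown, and "the series" means these compounds.

Measured so far:
- compound 1 `CCN1CCN(c2cccc3c2CN([C@H](CCCNC(=O)c2c(C)n[nH]c2C)c2ccc(OC)c(OC)c2)C3=O)CC1`: 16 nM
- compound 2 `COc1ccc([C@@H](CCCN(C)S(=O)(=O)c2cccs2)N2Cc3c(cccc3N3CCN(C)CC3)C2=O)cc1OC`: 16 nM

Both compounds were tested in a functional assay on CHO-K1 cells for antagonist activity at Urotensin-2 receptor (Rattus norvegicus), read by FLIPR and calcium flux, with a stated time of 1 h; a lower number here means a stronger inhibitor, a higher number a weaker inhibitor. Compound 1 gives 16 nM there, and compound 2 gives 16 nM; at the digits shown the two stand level, within the usual scatter of repeated measurements, so neither can be called the stronger inhibitor.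

Compound 3 `CCN1CCN(c2cccc3c2CN([C@H](CCCNC(=O)c2cccs2)c2ccc(OC)c(OC)c2)C3=O)CC1` has not been measured. It keeps the shared core of compound 1 and differs in one place: thiophen-2-yl in place of 3,5-dimethyl-1H-pyrazol-4-yl on a carbonyl carbon. For the measured compounds named here, no pair of measured compounds shows this exact change, so its effect has to be guessed from the neighbourhood alone. Compound 2, which carries a thiophene on a different kind of linking group, sits at the same level as compound 1, which gives no sign that the side-chain aromatic ring drives large swings here.

A step from compound 1 to compound 3 of a 1.3-fold higher number from compound 1 to compound 3 (0.10 log units; within the scatter) is therefore expected, essentially none beyond the scatter. Compound 3 is estimated at 20 nM, within a range of 6 nM to 65 nM.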

Compound 3, half-maximal inhibitory concentration: 7 nM
The estimate for compound 3 lay 2.9-fold (0.46 log units) above the measured number, within the range that was stated.
By their numbers in this assay, from the lowest: compound 3; then compounds 1 and 2 (each within the scatter of the next).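

In this assay, for the compounds shown here, exchanging the 3,5-dimethyl-1H-pyrazol-4-yl ring for a thiophen-2-yl ring gives a 2.3-fold lower number from compound 1 to compound 3 (0.36 log units; beyond the scatter) and so provides the first reading of a change at a single place. The step is modest, but it shows that the number responds to the ring at this position. It also shows that a hydrogen-bond donor on this ring is not required for a low number, as thiophen-2-yl has 0 hydrogen-bond donors. No measurement here explains the difference.

From the compounds shown here alone, the change alters the ring atoms, the two methyl groups and the donor together, so their separate contributions remain open. A phenyl or furan-2-yl ring at the same place would test whether the lower number is specific to thiophen-2-yl.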